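The source may hold more compounds than are shown below. What is called first, only, known or untested is meant among the compounds shown, and "the series" means these compounds.

Compound 1 `Cc1nc(C#Cc2cc(Br)cc(C#N)c2)cs1` gives 1.06 nM in a functional assay on HEK293 cells for antagonist activity at metabotropic glutamate receptor 5 (Rattus norvegicus), read by calcium flux; on this read-out higher numbers stand for weaker inhibition and lower numbers for stronger inhibition. Compound 2 `Cc1nc(C#Cc2cc(Br)cc(Br)c2)cs1` gives 1.45 nM in this assay. Compound 3 `N#Cc1cc(C#Cc2ccccn2)cc([N+](=O)[O-])c1` gives 1.32 nM in this assay.

Compound 1 and compound 2 differ by one change, (bromo in place of cyano on an aromatic carbon). That change made the step of a 1.4-fold higher number from compound 1 to compound 2 (0.14 log units; within the scatter). Compound 4 `O=[N+]([O-])c1cc(Br)cc(C#Cc2ccccn2)c1` is not yet measured; it differs from compound 3 by bromo in place of cyano on an aromatic carbon. This is the same kind of change, not the same: in compound 1 the place is meta to a bromo group, while in compound 3 it is meta to a nitro group. How the core of compound 1 and the core of compound 3 differ is not broken down here. For compound 4 a step like a 1.4-fold higher number from compound 3 to compound 4 (0.16 log units; within the scatter) in this assay is expected, resting on the earlier step of a 1.4-fold higher number from compound 1 to compound 2 (0.14 log units; within the scatter). The estimate for compound 4 is 1.9 nM, between 0.7 nM and 5 nM.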

Compound 4, half-maximal inhibitory concentration: 0.39 nM
For compound 4 the middle estimate is 4.9-fold (0.69 log units) above the measured one; the measured number lies below the stated range.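

Replacing cyano with bromo gave a 3.4-fold lower number from compound 3 to compound 4 (0.53 log units; beyond the scatter), which does not follow the step seen on the other core. The two steps do not match in this assay: the same change on two cores in this assay, a 1.4-fold higher number (0.14 log units; within the scatter) from compound 1 to compound 2 and a 3.4-fold lower number (0.53 log units; beyond the scatter) from compound 3 to compound 4, 4.6-fold (0.67 log units) apart, beyond the scatter of two such steps. So the size of this change cannot simply be carried from one core to another in this series, but two pairs do not show which difference between the cores matters, or how the change would behave on a further core.

The compounds shown leave open how a different group at this place, such as an amine or a carboxylic acid, would compare on either core. They also leave open whether either step is typical of this change.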